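From cyclopropyl to thiophen-3-yl: compound 2 to compound 4

This account rests on a few compounds, and the source may have more. Where it says the series, first, only, none or still open, it means among the compounds named here.

Measured so far in a physicochemical assay for solubility, at pH 7; a higher number here means a more soluble compound, a lower number a less soluble compound:
- compound 1 `CC(=O)N1CCN(C(=O)N2Cc3c(NC(=O)c4ccc(F)cc4)n[nH]c3C2(C)C)CC1` gives > 225000 nM as a limit
- compound 2 `CN1CCC(C(=O)N2Cc3c(NC(=O)C4CC4)n[nH]c3C2(C)C)CC1` gives > 225000 nM as a limit
- compound 3 `CC(C)(C)C(=O)N1Cc2c(NC(=O)C3CCNCC3)n[nH]c2C1(C)C` gives > 225000 nM as a limit

Compound 2 stands at > 225000 nM in this assay as a limit and not a number. It does not stand alone, and the limit of > 225000 nM in this assay, at which 3 of the 3 values shown sit, is the only summary these data allow. Going by the values given here, no measured pair differs in one place, so no step size has yet been observed, and the three limits cannot be ranked against one another.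

Compound 4 `CN1CCC(C(=O)N2Cc3c(NC(=O)c4ccsc4)n[nH]c3C2(C)C)CC1` is the next compound to be read. Its difference from compound 2 is thiophen-3-yl in place of cyclopropyl on a carbonyl carbon in one place, thiophen-3-yl in place of cyclopropyl on a carbonyl carbon.

Among the compounds with values here, with no measured step to draw on, the expectation is a modest fall or no change beyond the scatter. The expected step is an at least 1.3-fold lower number from compound 2 to compound 4 (0.12 log units; that floor lies within the scatter) as estimated here, and a large fall is not expected. Compound 4 is estimated at 170000 nM with an expected range of 70000 nM to 225000 nM in this reading, and a report of only a limit is more likely than not.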

Compound 4, solubility: > 225000 nM
Compound 4 gave a limit, no number; the forecaster's own chance of this, stated with the estimate: 60%; at least 1.3-fold (0.12 log units) between middle value and limit.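

In this assay compound 4 gives > 225000 nM, a limit and not a number. Going by these compounds alone, compound 2 also sits at a limit, so no step from compound 2 to compound 4 can be read. The compounds shown leave open how far each lies past that limit, and so whether thiophen-3-yl in place of cyclopropyl changes the read-out at all: the limit of > 225000 nM in this assay, at which 4 of the 4 values shown sit.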